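Ethoxycarbonyl to 4-nitrophenyl on the side chain

The compounds below may be only part of what the source reports. "The series", "measured", "known", "first", "only" and "open" are said of these compounds alone.

Measured in a functional assay (B cells) with Mus musculus as the target; a lower number here means that less compound is needed, a higher number that more compound is needed for the effect:
compound 1 `Nc1nc(O)c2c(n1)n(C1OC(CO)[C@@H](O)[C@H]1O)c(=O)n2C/C=C/c1ccccc1`: 103 uM
compound 2 `CN(C)CCCn1c(=O)n(C2OC(CO)[C@@H](O)[C@H]2O)c2nc(N)nc(O)c21`: 194 uM
compound 3 `CCOC(=O)Cn1c(=O)n(C2OC(CO)[C@@H](O)[C@H]2O)c2nc(N)nc(O)c21`: 48 uM

Compound 3 stands lowest of the three at 48 uM, beyond the scatter from both others.

Compound 4 `Nc1nc(O)c2c(n1)n(C1OC(CO)[C@@H](O)[C@H]1O)c(=O)n2Cc1ccc([N+](=O)[O-])cc1` keeps the shared core and carries 4-nitrophenyl in place of ethoxycarbonyl on a saturated chain carbon bound to an aromatic nitrogen.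

Among the measured compounds shown here, no measured step makes this exact exchange. For the measured compounds named here, the closest is the one that replaces 2-phenylethenyl, the only measured group with an aromatic ring, by ethoxycarbonyl: a 2.1-fold lower number from compound 1 to compound 3 (0.33 log units; beyond the scatter). Read in reverse, it points to a higher number when a ring-bearing group displaces ethoxycarbonyl. The exchange of 2-(dimethylamino)ethyl for ethoxycarbonyl points the same way, as the ester-bearing compound again gives the lower number: a 4.0-fold lower number from compound 2 to compound 3 (0.61 log units; beyond the scatter). The remaining step, a 1.9-fold higher number from compound 1 to compound 2 (0.27 log units; within the scatter), stays within the scatter and gives no direction. Three compounds support this only weakly, and none has the nitro group.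

A modest rise in this assay is therefore expected, close to the size of the closest step. The expected step is a 2.1-fold higher number from compound 3 to compound 4 (0.32 log units; beyond the scatter). The estimate for compound 4 is 100 uM, with an expected range from 40 uM to 230 uM.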

Compound 4, concentration for half-maximal effect: 40 uM
Estimate against measurement, compound 4: 2.5-fold (0.40 log units) above, within the range that was stated.
By their numbers in this assay, from the lowest: compounds 4 and 3 (each within the scatter of the next); then compounds 1 and 2 (each within the scatter of the next).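

In this assay, the exchange of ethoxycarbonyl for 4-nitrophenyl on a saturated chain carbon bound to an aromatic nitrogen gives a 1.2-fold lower number from compound 3 to compound 4 (0.08 log units; within the scatter) and so leaves compound 3 and compound 4 indistinguishable, which shows that a group with an aromatic ring can sit at this place on a par with the ester. An aromatic ring alone therefore does not set the number, since the step of a 2.6-fold lower number from compound 1 to compound 4 (0.41 log units; beyond the scatter) separates two ring-bearing side chains, while the step of a 4.9-fold lower number from compound 2 to compound 4 (0.69 log units; beyond the scatter) puts 4-nitrophenyl clear of 2-(dimethylamino)ethyl in the same way as the ester. Nothing measured here bears on the reason for these differences.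

The compounds shown leave open what the nitro group contributes to the number of compound 4, which an unsubstituted benzyl or a 4-aminobenzyl at the same place would test. They also leave open whether the ethyl of the ester matters, as a free carboxylic acid or a primary amide there would show.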